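The source may report more compounds than this note shows. Statements on the series, on what has been measured and on what is new or still open speak of the compounds shown alone.

Compounds measured in an ADME assay on microsomes from liver (Rattus norvegicus), read by LC-MS, with a stated time of 60 min, tested at 1 uM; on this read-out higher numbers stand for higher hepatic extraction and lower numbers for lower hepatic extraction:

compound 1, `O=C1Cc2cc(-c3c(-c4ccc(F)cc4)nn4c(N5CCC(F)CC5)nccc34)ccc2N1`: 0.6
compound 2, `O=C1CN(c2nccc3c(-c4ccc5c(c4)CC(=O)N5)c(-c4ccc(F)cc4)nn23)CCN1`: 0.6

Among the compounds with values here, compound 2 stands level with compound 1 in this assay; the one step recorded, no change at the digits printed from compound 1 to compound 2 (within the scatter), lies within the scatter, so exchanging the group on this aromatic carbon of the shared core has left the read-out where it was.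

Compound 3, `CC(=O)N1CCN(c2nccc3c(-c4ccc5c(c4)CC(=O)N5)c(-c4ccc(F)cc4)nn23)CC1`, is not yet measured. It differs from compound 2 by 4-acetylpiperazin-1-yl in place of 3-oxopiperazin-1-yl on an aromatic carbon.

Within the data shown here, only the step from compound 1 to compound 2 bears on this change, since it alters the same position of the same core, and it was flat. Among the measured compounds shown here, no measured step shows what the acetyl group on the piperazine adds, so the expectation rests on that single flat step. The expected step a number 0.050 higher from compound 2 to compound 3 (within the scatter) is therefore small, with no direction beyond the scatter. Compound 3 is estimated at 0.65, with a range of 0.5 to 0.8.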

Compound 3, hepatic extraction ratio: 0.5
Compound 3: middle estimate off by 0.15, on the high side, within the range that was stated.
By their numbers in this assay, from the lowest: compounds 3, 1 and 2 (each within the scatter of the next).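

Across the three groups now seen on the aromatic carbon between two ring nitrogen atoms, this assay gives steps that all stay within the scatter: a number 0.10 lower from compound 2 to compound 3 (within the scatter) and a number 0.10 lower from compound 1 to compound 3 (within the scatter) are the new ones. The exchange of 3-oxopiperazin-1-yl for 4-acetylpiperazin-1-yl gives up the hydrogen-bond donor of the leaving group and brings in a larger group by heavy atoms, and neither difference separates the compounds beyond the scatter on this read-out. No measurement at hand accounts for the close readings of these groups.

Going by these compounds, whether a group of another kind at this place, such as an open-chain amine or a carboxylic acid, would give a step beyond the scatter remains open. On these data alone, all three compounds also share the rest of the core, so whether these readings would hold on a different core is untested here.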